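Swapping the amide arm of compound 1 for a fluorobenzyl group

The compounds below may be only part of what the source reports. "The series", "measured", "known", "first", "only" and "open" are said of these compounds alone.

Measured compounds:
compound 1, `CCN1CCN(CCCn2cnc3c(N4CCN(C5CCCC5)CC4)nc(NC(=O)c4ccc(CN(C)C)cc4)nc32)CC1`, 60 nM
compound 2, `CCN1CCN(CCCn2cnc3c(N4CCN(CC)CC4)nc(NCc4ccc(OC)cc4)nc32)CC1`, 200 nM
compound 3, `CCN1CCN(CCCn2cnc3c(N4CCN(C(=O)C5CCCC5)CC4)nc(NCc4ccc(N(CC)CC)cc4)nc32)CC1`, 8800 nM

In an assay on HEK293 cells for antagonist activity at Toll-like receptor 9 (Homo sapiens), read by spectrophotometry (on this read-out lower numbers stand for stronger inhibition and higher numbers for weaker inhibition), compound 1 gives the lowest number of the three. Compound 2 sits nearest to it, with a number that is higher and beyond the scatter, while compound 3 lies far beyond it. Compound 1 therefore stands as the most potent of these measured compounds in this assay.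

The next compound, compound 4, `CCN1CCN(CCCn2cnc3c(N4CCN(C5CCCC5)CC4)nc(NCc4ccc(F)cc4)nc32)CC1`, has not yet been measured in this assay. It keeps the shared core of compound 1 and differs from it in one place: 4-fluorobenzyl in place of (4-((dimethylamino)methyl)phenyl)carbonyl on a nitrogen on an aromatic ring. The group that leaves carries a carbonyl and two hydrogen-bond acceptors; the group that enters carries none.

For the measured compounds named here, no step between two measured compounds isolates this exact exchange. Compound 2 carries a substituted benzyl on the same ring nitrogen and gives 200 nM, a weaker number than compound 1. On that basis compound 4 is expected to lose some potency, with a step of a 3.3-fold higher number from compound 1 to compound 4 (0.52 log units; beyond the scatter) expected, larger than the scatter. The estimate for compound 4 in this assay is 200 nM, with a range from 60 nM to 700 nM.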

Compound 4, half-maximal inhibitory concentration: 250 nM
Compound 4: the middle estimate sits 1.3-fold (0.10 log units) below what was measured, and the stated range covers the measured number.
By their numbers in this assay, from the lowest: compound 1; then compounds 2 and 4 (each within the scatter of the next); then compound 3.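

In this assay, for the compounds shown here, this is the first step that isolates the group on the nitrogen on an aromatic ring: with the rest of the core of compound 1 unchanged, 4-fluorobenzyl in place of (4-((dimethylamino)methyl)phenyl)carbonyl gives a 4.2-fold higher number from compound 1 to compound 4 (0.62 log units; beyond the scatter) and so counts as a modest loss. The position therefore responds to what it carries, yet compound 4 still gives 250 nM with no carbonyl and no hydrogen-bond acceptors in that arm, which shows that inhibition survives without them. No independent measurement is available to explain the step.

The exchange removes the carbonyl and the dimethylamino group and adds the fluorine all at once, so the compounds shown do not separate what each of these changes contributes. Going by these compounds, it remains open whether a 4-((dimethylamino)methyl)benzyl group on that nitrogen, which keeps the amine and drops only the carbonyl, or a 4-fluorobenzoyl group, which keeps the carbonyl and drops only the amine, would stay closer to compound 1 or to compound 4.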